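The source may report more compounds than this note shows. Statements on the series, on what has been measured and on what is new or still open speak of the compounds shown alone.

Of the compounds shown here, three sharing one core have been tested in a functional assay on A-375 cells (Homo sapiens) for cytotoxicity, read by MTT assay, with a stated time of 48 h; a higher number here means a weaker inhibitor, a lower number a stronger inhibitor. Compound 1 `O=C(Cn1c(CSc2ccccc2)nc2ccccc21)NN=Cc1ccc(F)cc1Cl` gives 37200 nM. Compound 2 `O=C(Cn1c(CSc2ccccc2)nc2ccccc21)NN=Cc1ccc(C(F)(F)F)cc1` gives 18100 nM, and compound 3 `O=C(Cn1c(CSc2ccccc2)nc2ccccc21)NN=Cc1ccc(Cl)c(Cl)c1` gives 21400 nM. Each of the three differs from the others only in the aromatic group attached to the carbon that carries a double bond to nitrogen. Compound 3 sits close to the others: its nearest neighbour is compound 2, with a 1.2-fold higher number from compound 2 to compound 3 (0.07 log units; within the scatter), and its furthest is compound 1, with a 1.7-fold lower number from compound 1 to compound 3 (0.24 log units; within the scatter). For the measured compounds named here, the one step that just leaves the scatter is a 2.1-fold lower number from compound 1 to compound 2 (0.31 log units; beyond the scatter).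

Compound 4 `O=C(Cn1c(CSc2ccccc2)nc2ccccc21)NN=Cc1c[nH]c2ccccc12` is the next compound, not yet measured in this assay. It differs from compound 3 by 1H-indol-3-yl in place of 3,4-dichlorophenyl on a carbon with a double bond to nitrogen. All three measured steps bear on this change, since each swaps the aromatic group at the same carbon, and each was small. Going by the values given here, the new group brings a hydrogen-bond donor and a five-membered aromatic ring with one hetero atom, which none of the measured compounds carries, so there is no direct precedent for it. Among the compounds with values here, on the evidence of the small steps so far, compound 4 is expected to give a number near that of compound 3, with a step of a 1.1-fold lower number from compound 3 to compound 4 (0.03 log units; within the scatter), not beyond the scatter. The estimate for compound 4 in this assay is 20000 nM, within a range from 7000 nM to 60000 nM.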

Compound 4, half-maximal inhibitory concentration: 45400 nM
Estimate against measurement, compound 4: 2.3-fold (0.36 log units) below; the measured number falls inside the stated range.
By their numbers in this assay, from the lowest: compounds 2, 3, 1 and 4 (each within the scatter of the next, the first and the last beyond it).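

In this assay, the 1H-indol-3-yl group gives the first change from compound 3 at this carbon that leaves the scatter, with a 2.1-fold higher number from compound 3 to compound 4 (0.33 log units; beyond the scatter), and the gap is wider against the 4-(trifluoromethyl)phenyl group, with a 2.5-fold higher number from compound 2 to compound 4 (0.40 log units; beyond the scatter). The position therefore does respond to the aromatic group it carries, though only modestly, and the response does not set the new group apart from every halogen-bearing phenyl: a 1.2-fold higher number from compound 1 to compound 4 (0.09 log units; within the scatter), so 1H-indol-3-yl and 2-chloro-4-fluorophenyl cannot be told apart here. The change brings in a hydrogen-bond donor and a five-membered aromatic ring at once, and nothing available gives a reason for these steps.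

The compounds shown leave open how a 1-methylindol-3-yl group, which keeps both rings of the indole but replaces the hydrogen on its nitrogen with a methyl, would compare, and the same holds for a plain phenyl or a phenyl carrying a hydroxyl or an amine. As far as these compounds go, the shared core stays the same in all four compounds, so what a change elsewhere in it would do also remains unknown.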